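From Dipropylamino to Dipentylamino in a Flat Series

The compounds below may be only part of what the source reports. "The series", "measured", "known", "first", "only" and "open" are said of these compounds alone.

In a functional assay on LNCaP cells (Homo sapiens) for antiproliferative activity, read by WST assay, with a stated time of 3 days (a lower number here means a stronger inhibitor, a higher number a weaker inhibitor), compound 1 (`CCCCOc1c(-c2cc(OC)c(OC)c(OC)c2)oc2ccccc2c1=O`) gives 8900 nM and compound 2 (`CCN(CC)CCCCOc1c(-c2cc(OC)c(OC)c(OC)c2)oc2ccccc2c1=O`) gives 13500 nM while compound 3 (`CCCN(CCC)CCCCCOc1c(-c2cc(OC)c(OC)c(OC)c2)oc2ccccc2c1=O`) gives 7600 nM as its reading. Compound 3 cannot be told apart from either of the other two, since both steps to it lie within the scatter (a 1.2-fold lower number from compound 1 to compound 3 (0.07 log units; within the scatter); a 1.8-fold lower number from compound 2 to compound 3 (0.25 log units; within the scatter)). Compound 4 (`CCCCCN(CCCCC)CCCCOc1c(-c2cc(OC)c(OC)c(OC)c2)oc2ccccc2c1=O`) differs from it by one exchange (dipentylamino in place of (dipropylamino)methyl on a saturated chain carbon, four bonds along the chain from an oxygen on an aromatic ring) with dipentylamino in place of (dipropylamino)methyl on a saturated chain carbon, four bonds along the chain from an oxygen on an aromatic ring. Among the measured compounds shown here, no measured compound carries dipentylamino. The nearest evidence is the exchange of amine groups at that place (a 1.8-fold lower number from compound 2 to compound 3 (0.25 log units; within the scatter)) together with the step from the plain chain (a 1.5-fold higher number from compound 1 to compound 2 (0.18 log units; within the scatter)), and both stay within the scatter. No step beyond the scatter is therefore expected in this assay and the estimate is a small one (a 1.0-fold lower number from compound 3 to compound 4 (0.01 log units; within the scatter)). Compound 4 is expected near 7500 nM (estimated range 3200 nM to 16000 nM).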

Compound 4, half-maximal inhibitory concentration: 9700 nM
For compound 4 the middle estimate is 1.3-fold (0.11 log units) below the measured one; low and high end bracket the measured number.
By their numbers in this assay, from the lowest: compounds 3, 1, 4 and 2 (each within the scatter of the next).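

In this assay, dipentylamino on a saturated chain carbon, four bonds along the chain from an oxygen on an aromatic ring, adds a larger amine to the set, and compound 4 still cannot be told apart from any earlier compound (a 1.3-fold higher number from compound 3 to compound 4 (0.11 log units; within the scatter)), (a 1.4-fold lower number from compound 2 to compound 4 (0.14 log units; within the scatter)) and (a 1.1-fold higher number from compound 1 to compound 4 (0.04 log units; within the scatter)). Across these compounds, neither an amine in place of the plain chain end nor the exchange of one amine for another gives a step beyond the scatter, so the flat picture now extends to dipentylamino. Nothing available here accounts for this flatness.

From the compounds shown here alone, whether a cyclic amine such as piperidine or morpholine, or a carboxylic acid in place of the amine, would move the reading beyond the scatter stays open. So does the effect of a shorter chain carrying the amine.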